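A few compounds are considered here, and "the series" means these few. Any claim that something is new, unique, unknown or untested is made for them only; others in the source may bear on it.

In an assay on isolated protein for inhibition of DNA topoisomerase 1 (Homo sapiens), with a stated time of 30 min, tested at 20 uM (on this read-out higher numbers stand for a stronger effect at the one concentration tested and lower numbers for a weaker effect), compound 1 `Oc1ccc(-c2cc(-c3cccs3)cc(-c3ccccc3O)n2)cc1` gives 2%. Compound 2 `Oc1ccccc1-c1cc(-c2ccoc2)cc(-c2ccccc2O)n1` gives "not determined" (no result reported) in this assay, and compound 3 `Oc1cccc(-c2cc(-c3ccoc3)cc(-c3ccccc3O)n2)c1` likewise gives "not determined" (no result reported). Compound 3 therefore stands without a number in this assay, alongside one further compound that also has none. Compound 4 `Oc1ccc(-c2cc(-c3ccoc3)cc(-c3ccccc3O)n2)cc1` is to be measured in this assay; it differs from compound 3 by 4-hydroxyphenyl in place of 3-hydroxyphenyl on an aromatic carbon. Among the measured compounds shown here, no step from compound 3 to compound 4 can be sized, since compound 3 has no value; any difference is expected to stay within the usual scatter. As compound 1 carries the same 4-hydroxyphenyl group and gives 2%, compound 4 is expected to give 4%, with a range from 0% to 15%.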

Compound 4, a percentage reported as inhibition, at one concentration (the size of the read-out at that concentration, not a potency): 3.9%
Compound 4: the middle estimate sits 0.1 percentage points above what was measured; low and high end bracket the measured number.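

In this assay, exchanging thiophen-2-yl for furan-3-yl while the 4-hydroxyphenyl group stays in place gives a number 1.9 percentage points higher from compound 1 to compound 4 (within the scatter), so the two rings cannot be told apart at the one concentration tested. The exchange of 3-hydroxyphenyl for 4-hydroxyphenyl cannot be read, as compound 3 has no number, and the step to compound 2 cannot be read either. No measurement on hand accounts for the result. The compounds shown leave open whether an amine or a carboxylic acid in place of the hydroxyphenyl group next to the ring nitrogen would give a read-out beyond the scatter of compound 1 and compound 4.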